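Amine variation on the aryl amide: towards compound 4

The source may report more compounds than this note shows. Statements on the series, on what has been measured and on what is new or still open speak of the compounds shown alone.

Measured so far in an assay on HEK293 cells for inhibition of Steryl-sulfatase (Homo sapiens), tested at 1 uM; on this read-out lower numbers stand for a weaker effect and higher numbers for a stronger effect at the one concentration tested:
compound 1 `CCCN(CCC)c1ccc(C(=O)N2CCc3ccc(OS(N)(=O)=O)cc3C2)cc1` — 84.7%
compound 2 `CCN(Cc1ccccc1)c1ccc(C(=O)N2CCc3ccc(OS(N)(=O)=O)cc3C2)cc1` — 83.6%
compound 3 `CCCN(Cc1ccccc1)c1ccc(C(=O)N2CCc3ccc(OS(N)(=O)=O)cc3C2)cc1` — 94.3%

Compound 3 gives the highest of the three numbers, but only its distance to compound 2 is beyond the scatter: a number 10.7 percentage points higher from compound 2 to compound 3 (beyond the scatter). Towards compound 1 it stands within the scatter, a number 9.6 percentage points higher from compound 1 to compound 3 (within the scatter), so compound 1 and compound 3 cannot be ordered. Compound 1 and compound 2 are likewise within the scatter of each other, a number 1.1 percentage points lower from compound 1 to compound 2 (within the scatter).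

Compound 4 `CN(CCN1CCCCC1)c1ccc(C(=O)N2CCc3ccc(OS(N)(=O)=O)cc3C2)cc1` carries the change (methyl(2-(piperidin-1-yl)ethyl)amino in place of benzyl(propyl)amino on an aromatic carbon).

All three measured steps concern the same amine on the aromatic ring, and none of them moves the read-out by more than a modest amount; the exchange of one substituent for another, a number 1.1 percentage points lower from compound 1 to compound 2 (within the scatter), stayed within the scatter, and the two steps into compound 3 were at most modest. For the measured compounds named here, no measured pair shows the loss of the aromatic ring from this amine or the entry of the piperidine-bearing chain, so the step to compound 4 is less covered than the earlier ones. On the evidence of how little the amine changes so far have moved this assay, a modest step downward or none beyond the scatter is expected, a number 16.3 percentage points lower from compound 3 to compound 4 (beyond the scatter). Compound 4 is therefore estimated at 78%, within 58% to 93%.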

Compound 4, a percentage reported as inhibition, at one concentration (the size of the read-out at that concentration, not a potency): 26.8%
The estimate for compound 4 lay 51.2 percentage points above the measured number; measured number outside the range, below it.
By their numbers in this assay, from the lowest: compound 4; then compounds 2, 1 and 3 (each within the scatter of the next, the first and the last beyond it).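

In this assay, for the compounds shown here, the amine on the aromatic carbon, para to a large group, proves far less tolerant than the earlier steps suggested: methyl(2-(piperidin-1-yl)ethyl)amino gives a number 67.5 percentage points lower from compound 3 to compound 4 (beyond the scatter) against benzyl(propyl)amino, a number 56.8 percentage points lower from compound 2 to compound 4 (beyond the scatter) against benzyl(ethyl)amino and a number 57.9 percentage points lower from compound 1 to compound 4 (beyond the scatter) against dipropylamino. The loss of the six-membered aromatic ring of carbon alone does not match this fall, since compound 1 carries no such ring in its amine and still gives 84.7%, so the fall goes with the entering group, which brings a six-membered non-aromatic ring with 1 hetero atom. Nothing available gives a reason for this fall.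

The compounds shown leave open whether the fall follows the piperidine ring itself, the ethyl chain that carries it or the methyl on the nitrogen. A morpholine ring on the same chain, or a pentyl chain in place of the whole piperidinylethyl group, would begin to separate these parts.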